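The source may report more compounds than this note shows. Statements on the series, on what has been measured and on what is new or still open speak of the compounds shown alone.

Of the compounds shown here, three built on one shared core have so far been measured in a toxicity assay on the whole organism (strain Icem-CET (SPF Caw)) for cytotoxicity, with Mus musculus as the target; a higher number here means that more compound is needed for the effect, a lower number that less compound is needed. Compound 1 `C#CCNC(=O)/C(C)=C(\C)c1cc(OC)c(OC)c(OC)c1` gives 300 mg/kg, and compound 3 `C=CCNC(=O)/C(C)=C(\C)c1cc(OC)c(OC)c(OC)c1` gives 280 mg/kg. Compound 2 `C/C(C(=O)NC1CC1)=C(/C)c1ccc(Br)cc1` gives 600 mg/kg, the highest of the three numbers; its nearest neighbour is compound 1, a gap within the scatter, while compound 3 gives a number lower than that of compound 2 by a margin beyond the scatter. Among the measured compounds shown here, the only step between two measured compounds that differ in a single place is a 1.1-fold lower number from compound 1 to compound 3 (0.03 log units; within the scatter), a change on the saturated chain carbon bound to the amide-type nitrogen, and it is within the scatter.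

Compound 4 `C/C(C(=O)NC1CC1)=C(/C)c1ccccc1` differs from compound 2 in one place: hydrogen in place of bromo on an aromatic carbon. For the measured compounds named here, none of the measured steps bears on this change. Going by the values given here, the step from compound 1 to compound 3 concerns the chain group and not the aromatic ring, and no measured pair exchanges a bromo for hydrogen on the ring. With nothing to point in either direction, the expected step from compound 2 to compound 4 is no change at the digits printed from compound 2 to compound 4 (within the scatter), which is no change beyond the scatter. Compound 4 is therefore expected to give about 600 mg/kg in this assay, with a range from 300 mg/kg to 1200 mg/kg.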

Compound 4, dose for half-maximal effect: 250 mg/kg
Compound 4: middle estimate off by 2.4-fold (0.38 log units), on the high side; measured number below the stated range.
By their numbers in this assay, from the lowest: compounds 4, 3, 1 and 2 (each within the scatter of the next, the first and the last beyond it).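

In this assay the place on the aromatic carbon para to a large group now proves able to move the number: hydrogen in place of bromo gives a 2.4-fold lower number from compound 2 to compound 4 (0.38 log units; beyond the scatter) as a modest step, so in this pair the compound without bromine needs less compound for the effect. Among the compounds shown here, the only earlier step, a 1.1-fold lower number from compound 1 to compound 3 (0.03 log units; within the scatter) on the chain group, had stayed within the scatter and said nothing about the ring, so this is the first change in the set to move the number beyond the scatter. No measurement at hand bears on why the loss of bromo goes with the lower number.

The compounds shown leave open whether the step belongs to bromo alone or would also appear with another group at this place, such as chloro, an amine or a carboxylic acid. They also leave open whether the same exchange would behave alike with an allyl or propargyl chain on the amide nitrogen in place of the cyclopropyl group of compound 2 and compound 4.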